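This account rests on a few compounds, and the source may have more. Where it says the series, first, only, none or still open, it means among the compounds named here.

Measured so far:
- compound 1 `C=C1C(=O)O[C@@H]2CC(C)=C([C@@H](C)CCCOC(C)=O)[C@@H](OC(=O)COc3ccc(C(C)=O)cc3)[C@H]12`: 49600 nM
- compound 2 `C=C1C(=O)O[C@@H]2CC(C)=C([C@@H](C)CCCOC(C)=O)[C@@H](OC(=O)COc3cccc4cccnc34)[C@H]12`: 14300 nM

In a functional assay on SGC-7901 cells (Homo sapiens) for cytotoxicity, read by sulforhodamine B assay, with a stated time of 72 h (on this read-out higher numbers stand for weaker inhibition and lower numbers for stronger inhibition), compound 2 stands lowest of the two numbers, with compound 1 the nearest neighbour, a step of a 3.5-fold lower number from compound 1 to compound 2 (0.54 log units; beyond the scatter). Compound 3 `C=C1C(=O)O[C@@H]2CC(C)=C([C@@H](C)CCCOC(C)=O)[C@@H](OC(=O)COc3cccc4[nH]nnc34)[C@H]12` differs from compound 2 by a group of 9 heavy atoms (6 carbon, 3 nitrogen; one five-membered aromatic ring with 3 hetero atoms, one six-membered aromatic ring of carbon only) in place of a group of 10 heavy atoms (9 carbon, 1 nitrogen; one six-membered aromatic ring of carbon only, one six-membered aromatic ring with 1 hetero atom), on an oxygen on a saturated carbon. For the measured compounds named here, the only measured step on this oxygen, a 3.5-fold lower number from compound 1 to compound 2 (0.54 log units; beyond the scatter), was modest, and no step between two bicyclic groups exists here. An expected change of about a 1.0-fold higher number from compound 2 to compound 3 (0.02 log units; within the scatter), within the scatter, follows for compound 3. Compound 3 is therefore estimated at 15000 nM, with a range from 6000 nM to 40000 nM.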

Compound 3, half-maximal inhibitory concentration: 21100 nM
The estimate for compound 3 lay 1.4-fold (0.15 log units) below the measured number; low and high end bracket the measured number.
By their numbers in this assay, from the lowest: compounds 2 and 3 (each within the scatter of the next); then compound 1.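

In this assay, for the compounds shown here, the only step between two bicyclic groups on this oxygen (a 1.5-fold higher number from compound 2 to compound 3 (0.17 log units; within the scatter)) does not separate quinolin-8-yl from the group with the five-membered aromatic ring. A second bicyclic group also stands apart from the 4-acetylphenyl group, modestly (a 2.4-fold lower number from compound 1 to compound 3 (0.37 log units; beyond the scatter)), so the earlier gain is not confined to quinolin-8-yl. No measurement on hand explains either step. Still open, going by these compounds, is how this oxygen responds to a group with no aromatic ring, such as a simple amine or a carboxylic acid, or to a longer chain between the oxygen and the ring.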